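The source may report more compounds than this note shows. Statements on the series, on what has been measured and on what is new or still open speak of the compounds shown alone.

Of the compounds shown here, three have been measured in an assay on brain for displacement of a labelled ligand from Neuronal acetylcholine receptor; alpha4/beta2 (Rattus norvegicus); on this read-out higher numbers stand for weaker inhibition and lower numbers for stronger inhibition. Compound 1, `CN(C)C1(COc2ccc(Cl)nc2)CC1`, gives 304 nM. Compound 2, `CN(C)C1(COc2cncc(Br)c2)CC1`, gives 273 nM. Compound 3, `CNC1(COc2cnc(Cl)c(Br)c2)CC1`, gives 5.37 nM, the lowest of the three numbers and therefore the strongest binding seen so far; its nearest neighbour on the scale is compound 2, and its furthest is compound 1, both gaps lying well beyond the scatter. Among the compounds with values here, compound 1 and compound 2 each differ from compound 3 in more than one place, so no single step between them can be read off.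

The next compound, compound 4, `CN(C)C1(COc2cnc(Cl)c(Br)c2)CC1`, keeps the core of compound 3 and changes one thing: methyl in place of hydrogen on an amine nitrogen. Within the data shown here, no measured pair isolates this exact change, so the expectation rests on the structural change alone. Moving from a methylamino to a dimethylamino group is expected to weaken binding, and compound 4 is expected to show a step of a 9.3-fold higher number from compound 3 to compound 4 (0.97 log units; beyond the scatter) in this assay. On that basis compound 4 is estimated at 50 nM, with a likely range from 10 nM to 250 nM.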

Compound 4, inhibition constant: 110 nM
Estimate against measurement, compound 4: 2.2-fold (0.34 log units) below, and the stated range covers the measured number.
By their numbers in this assay, from the lowest: compound 3; then compound 4; then compounds 2 and 1 (each within the scatter of the next).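

In this assay, within the data shown here, methyl in place of hydrogen on the amine nitrogen gives a 20-fold higher number from compound 3 to compound 4 (1.31 log units; beyond the scatter) and is the first single change here that can be read on its own, showing that binding responds strongly to this one carbon. With the dimethylamino group in place, chloro in place of hydrogen on an aromatic carbon gives a 2.5-fold lower number from compound 2 to compound 4 (0.39 log units; beyond the scatter) and bromo in place of hydrogen on an aromatic carbon gives a 2.8-fold lower number from compound 1 to compound 4 (0.44 log units; beyond the scatter) as modest gains, so each halogen adds to binding, though by less than the nitrogen step takes away. No measurement shown here explains the size of any of these steps.

Going by these compounds, whether an ethyl group on the nitrogen would weaken binding further, or a bare amino group would change it in either direction, remains open. On these data alone, it is also open whether the two halogen steps would keep their size with the methylamino group, or whether fluoro would serve in place of chloro.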